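Swapping a bicyclic amide substituent for a pyridine

The compounds below may be only part of what the source reports. "The series", "measured", "known", "first", "only" and "open" are said of these compounds alone.

The set is built on one shared core, a phenyl-tetrazole joined through an acetamide to a variable group on the amide nitrogen. Compound 1 `O=C(Cn1nnc(-c2ccccc2)n1)NC1CC2CCC1C2` carries a saturated bicyclic group there; in an assay on HEK293 cells for activation of Kir3.1/Kir3.2 (Homo sapiens), read by thallium flux (on this read-out higher numbers stand for larger maximal responses and lower numbers for smaller maximal responses), compound 1 gives 13%, the lowest of the two numbers recorded. Compound 2 `Cc1cc(NC(=O)Cn2nnc(-c3ccccc3)n2)n(C(C)C)n1` carries a substituted pyrazole instead, and in this assay compound 2 gives 107%, a gap to compound 1 well beyond the scatter. Compound 3 `Cc1cc(NC(=O)Cn2nnc(-c3ccccc3)n2)n(C2CCS(=O)(=O)CC2)n1` differs from compound 2 only at the pyrazole nitrogen, and in this assay compound 3 gives only a limit, > 25%. The step that the limit leaves unreadable from compound 2 to compound 3 is therefore unreadable, as the limit of > 25% in this assay, at which 1 of the 3 values shown sits, records.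

Compound 4 `O=C(Cn1nnc(-c2ccccc2)n1)Nc1ccccn1` is the unmeasured neighbour of compound 1: a group of 6 heavy atoms (5 carbon, 1 nitrogen; one six-membered aromatic ring with 1 hetero atom) in place of a group of 7 heavy atoms (7 carbon; 2 five-membered non-aromatic rings of carbon only), on an amide-type nitrogen. Going by the values given here, no measured step mirrors this change exactly; the only guide is that compound 2, the other amide bearing a nitrogen-containing aromatic ring, reached 107% while compound 1 reached 13%. On that basis compound 4 is expected to lie well above compound 1, at an estimated 60% in this assay, within 20% to 105%. The expected step is a number 47 percentage points higher from compound 1 to compound 4 (beyond the scatter).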

Compound 4, largest response reached (Emax), in percent of the reference or control that the assay uses: "not active" (no number reported)
No number was reported for compound 4; there is nothing to compare the estimate with.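

Compound 4 is recorded only as not active, with no number, so no new step can be read between compound 1 and compound 4. The compounds shown leave open how pyridin-2-yl compares numerically with the other amide substituents, and where compound 3 truly stands, since its value is only a limit: the limit of > 25% in this assay, at which 1 of the 4 values shown sits.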